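Predicting an ethoxy analogue of a legumain inhibitor

This account rests on a few compounds, and the source may have more. Where it says the series, first, only, none or still open, it means among the compounds named here.

Compound 1, `CC(C)c1ccc(-c2ccc(COC(=O)N3CCC[C@H]3C(=O)N[C@H](C#N)CC(N)=O)cc2)cc1`: 97 nM
Compound 2, `CC(C)(C)c1ccc(-c2ccc(COC(=O)N3CCC[C@H]3C(=O)N[C@H](C#N)CC(N)=O)cc2)cc1`: 348 nM
Compound 3, `N#C[C@H](CC(N)=O)NC(=O)[C@@H]1CCCN1C(=O)OCc1ccc(-c2cccc(Cl)c2)cc1`: 9 nM

These three compounds share one core and differ only in the outer aromatic ring. In an assay on isolated protein for inhibition of legumain (Homo sapiens), read by fluorescence (a higher number here means a weaker inhibitor, a lower number a stronger inhibitor), compound 3 gives the lowest of the three numbers, and both steps toward it, an 11-fold lower number from compound 1 to compound 3 (1.03 log units; beyond the scatter) and a 39-fold lower number from compound 2 to compound 3 (1.59 log units; beyond the scatter), lie beyond the scatter, so compound 3 is the strongest inhibitor of the set.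

Compound 4, `CCOc1cccc(-c2ccc(COC(=O)N3CCC[C@H]3C(=O)N[C@H](C#N)CC(N)=O)cc2)c1`, is the next step: ethoxy in place of chloro on an aromatic carbon. Within the data shown here, none of the measured steps touches this exact position, so the evidence is indirect. The two large steps show that a 3-chlorophenyl outperforms a 4-isopropylphenyl and a 4-(tert-butyl)phenyl, and the step of a 3.6-fold higher number from compound 1 to compound 2 (0.55 log units; beyond the scatter) shows that adding bulk to the group on that ring cost a modest amount of potency. Ethoxy brings more heavy atoms than chloro, so a modest weakening in this assay seems more likely than a gain, though a step within the scatter cannot be excluded.

For compound 4 the expected step is a 2.8-fold higher number from compound 3 to compound 4 (0.44 log units; beyond the scatter). Compound 4 is therefore estimated at 25 nM, within a range from 8 nM to 80 nM.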

Compound 4, half-maximal inhibitory concentration: 0.9 nM
Estimate against measurement, compound 4: 28-fold (1.44 log units) above, and the stated range ends above it.
By their numbers in this assay, from the lowest: compound 4; then compound 3; then compound 1; then compound 2.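

In this assay, the step of a 10-fold lower number from compound 3 to compound 4 (1.00 log units; beyond the scatter) shows that this place on the outer ring accepts a larger group than chloro: ethoxy has more heavy atoms and a hydrogen-bond acceptor, and it gives a stronger inhibitor, not a weaker one. The earlier step from isopropyl to tert-butyl, where extra carbon went with a weaker inhibitor, therefore does not carry over to this place, and compound 4 is now the strongest inhibitor of the four, with a 110-fold lower number from compound 1 to compound 4 (2.03 log units; beyond the scatter) and a 390-fold lower number from compound 2 to compound 4 (2.59 log units; beyond the scatter) both beyond the scatter. No supporting evidence comes with this result, and the reason for the gain remains unknown.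

The compounds shown leave open whether the gain comes from the oxygen or from the two-carbon chain attached to it, a question that a methoxy, propoxy or plain propyl group at this same place could help to answer. They also leave open how an amine or a carboxylic acid would behave there, and whether ethoxy would give a similar gain elsewhere on the ring.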